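Amide side-chain variation on a shared core

A few compounds are considered here, and "the series" means these few. Any claim that something is new, unique, unknown or untested is made for them only; others in the source may bear on it.

Measured compounds:
compound 1 `CCC(=O)N1CC2CC(C1)N2` — 490 nM
compound 2 `CC(C)C(=O)N1CC2CC(C1)N2` — 19000 nM
compound 3 `O=C(CC1C=CCC1)N1CC2CC(C1)N2` — 14000 nM

In an assay on SH-EP1 cells for agonist activity at Neuronal acetylcholine receptor; alpha4/beta2 (Homo sapiens), read by FLIPR and calcium flux (a higher number here means that more compound is needed for the effect, a lower number that less compound is needed), compound 2 gives 19000 nM, which lies within the usual scatter of compound 3 at 14000 nM, while compound 1 at 490 nM sits far lower. Compound 4 `O=C([C@H]1C[C@@H]1F)N1CC2CC(C1)N2` differs from compound 2 by 2-fluorocyclopropyl in place of isopropyl on a carbonyl carbon. For the measured compounds named here, two measured steps bear on this: a 39-fold higher number from compound 1 to compound 2 (1.59 log units; beyond the scatter) and a 29-fold higher number from compound 1 to compound 3 (1.46 log units; beyond the scatter), both large increases when the chain carbon on the carbonyl gains a methyl or a cyclopent-2-en-1-yl. The entering group again carries more than a single carbon on the carbonyl, but as a three-membered ring rather than the isopropyl, so a position between compound 1 and compound 2 seems plausible. Compound 4 is estimated at 5000 nM (range 1000 nM to 25000 nM). This corresponds to an expected 3.8-fold lower number from compound 2 to compound 4 (0.58 log units; beyond the scatter).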

Compound 4, half-maximal effective concentration: 850 nM
Compound 4: middle estimate off by 5.9-fold (0.77 log units), on the high side; the whole stated range lies above it.
By their numbers in this assay, from the lowest: compounds 1 and 4 (each within the scatter of the next); then compounds 3 and 2 (each within the scatter of the next).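

Replacing isopropyl with 2-fluorocyclopropyl on this carbonyl carbon gives a 22-fold lower number from compound 2 to compound 4 (1.35 log units; beyond the scatter), so a group with more heavy atoms here need not carry the high number of compound 2. Against the ethyl of compound 1, the same group gives a 1.7-fold higher number from compound 1 to compound 4 (0.24 log units; within the scatter), which keeps compound 4 level with compound 1. No supporting data on the origin of this difference are available. Whether the fluorine or the three-membered ring accounts for the step remains open. Also open, going by these compounds, are the plain cyclopropyl group, the opposite stereoisomer of 2-fluorocyclopropyl, and a methoxymethyl chain at this position.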